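Changing the Aryl Group on the Ring Nitrogen

The source may hold more compounds than are shown below. What is called first, only, known or untested is meant among the compounds shown, and "the series" means these compounds.

Compound 1 `N#CC1=C(N)Oc2c(N)cc3nc4ccccc4nc3c2C12C(=O)N(Cc1cnnn1-c1ccccc1Br)c1ccccc12`: 12400 nM
Compound 2 `N#CC1=C(N)Oc2c(N)cc3nc4ccccc4nc3c2C12C(=O)N(Cc1cnnn1-c1cccc(C(F)(F)F)c1)c1ccccc12`: 18900 nM

Among the compounds with values here, in a functional assay on HCT-116 cells (Homo sapiens) for antiproliferative activity, read by MTT assay, with a stated time of 48 h (a higher number here means a weaker inhibitor, a lower number a stronger inhibitor), compound 2 gives 18900 nM, the highest of the two numbers, and the only other measured compound lies close: a 1.5-fold higher number from compound 1 to compound 2 (0.18 log units; within the scatter). Compound 3 `CC(=O)Nc1ccc(-n2nncc2CN2C(=O)C3(C(C#N)=C(N)Oc4c(N)cc5nc6ccccc6nc5c43)c3ccccc32)cc1` differs from compound 2 in one place: 4-acetamidophenyl in place of 3-(trifluoromethyl)phenyl on an aromatic nitrogen. Within the data shown here, the single measured step, a 1.5-fold higher number from compound 1 to compound 2 (0.18 log units; within the scatter), also exchanged the group on that ring nitrogen and stayed within the scatter, so for compound 3 no step beyond the scatter is expected in this assay, a 1.3-fold lower number from compound 2 to compound 3 (0.10 log units; within the scatter). Compound 3 is therefore estimated at 15000 nM, with a range from 5000 nM to 45000 nM.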

Compound 3, half-maximal inhibitory concentration: > 50000 nM
Compound 3: no number, only a limit (the forecaster's own chance of this, stated with the estimate: 10%); middle value at least 3.3-fold (0.52 log units) away from the limit.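

In this assay compound 3 gives only a limit, not a number, > 50000 nM: the limit of > 50000 nM in this assay, at which 1 of the 3 values shown sits. Even so, the group on this ring nitrogen now moves the result beyond the scatter, with an at least 2.6-fold higher number from compound 2 to compound 3 (0.42 log units; beyond the scatter) and an at least 4.0-fold higher number from compound 1 to compound 3 (0.60 log units; beyond the scatter), which the earlier exchange of 2-bromophenyl for 3-(trifluoromethyl)phenyl did not do. Of the three groups shown, only 4-acetamidophenyl carries a hydrogen-bond donor and acceptor, though the three compounds cannot tie the step to these. Still open, on these data alone, is whether the step follows the acetamide itself or where it sits on the phenyl ring. A 3-acetamidophenyl, 4-aminophenyl or 4-methoxyphenyl group could help separate these.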